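From fluoro to acetamido in a cell toxicity test

The compounds below may be only part of what the source reports. "The series", "measured", "known", "first", "only" and "open" are said of these compounds alone.

Compound 1 `CC(=O)Nc1ccc(S(=O)(=O)N2C/C(=C\c3ccccc3F)C(=O)/C(=C/c3ccccc3F)C2)cc1` gives 11600 nM
Compound 2 `O=C1/C(=C/c2cccc([N+](=O)[O-])c2)CN(S(=O)(=O)c2ccc(F)cc2)C/C1=C\c1ccccc1F` gives 17000 nM

Both compounds were tested in an ADME assay on L02 cells (Homo sapiens) for cytotoxicity, read by MTT assay, with a stated time of 24 h (a lower number here means a stronger inhibitor, a higher number a weaker inhibitor), and compound 2 stands within the usual scatter of compound 1, so these two numbers cannot be told apart. Compound 3 `CC(=O)Nc1ccc(S(=O)(=O)N2C/C(=C\c3cccc([N+](=O)[O-])c3)C(=O)/C(=C/c3ccccc3F)C2)cc1` has not yet been measured. It differs from compound 2 by acetamido in place of fluoro on an aromatic carbon, para to a large group acetamido in place of fluoro on an aromatic carbon and the 4-fluorophenyl thus becomes 4-acetamidophenyl. Going by the values given here, no measured pair shows this change alone, so its size is unknown. Among the compounds with values here, the only hint is compound 1, which carries a 4-acetamidophenyl and gives 11600 nM in this assay as well. In this assay the expected step is a 1.3-fold lower number from compound 2 to compound 3 (0.12 log units; within the scatter) and that would lie within the scatter. The estimate for compound 3 is 13000 nM (expected range 6000 nM to 30000 nM).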

Compound 3, half-maximal inhibitory concentration: 18400 nM
Compound 3: middle estimate off by 1.4-fold (0.15 log units), on the low side; the range from low to high includes it.
By their numbers in this assay, from the lowest: compounds 1, 2 and 3 (each within the scatter of the next).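

In this assay, the 4-acetamidophenyl in place of the 4-fluorophenyl, with the rest of the molecule unchanged, gives a 1.1-fold higher number from compound 2 to compound 3 (0.03 log units; within the scatter) and so shows this position taking the acetamido group with no difference that can be told from scatter. The second new pair keeps the 4-acetamidophenyl and has 3-nitrophenyl in place of 2-fluorophenyl on a double-bonded chain carbon, giving a 1.6-fold higher number from compound 1 to compound 3 (0.20 log units; within the scatter) and so showing no readable difference at that place either. No measurement available here offers an explanation for these results.

From the compounds shown here alone, whether an amine or a carboxylic acid on the same aromatic carbon would also stay within the scatter remains open. So does the effect of a longer chain in place of the acetyl part of the acetamido group.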